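The compounds below may be only part of what the source reports. "The series", "measured", "known", "first", "only" and "open" are said of these compounds alone.

Measured in a functional assay on HCT-116 cells (Homo sapiens) for antiproliferative activity, read by MTT assay, with a stated time of 72 h; on this read-out higher numbers stand for weaker inhibition and lower numbers for stronger inhibition:
compound 1 `COc1cccc(N2C(=O)COc3ccc(-c4cnc(OC)c(NS(=O)(=O)c5ccc(F)cc5)c4)cc32)c1`: > 40000 nM (a limit)
compound 2 `COc1ncc(-c2ccc3c(c2)N(c2ccc(F)cc2)C(=O)CO3)cc1NS(=O)(=O)c1ccc(F)cc1`: > 40000 nM (a limit)
compound 3 `O=C1COc2ccc(-c3cnc(Cl)c(NS(=O)(=O)c4ccc(F)cc4)c3)cc2N1c1ccc(F)cc1`: 34200 nM

Compound 2 gives no number, only the limit > 40000 nM. The data show (the limit of > 40000 nM in this assay, at which 2 of the 3 values shown sit). Compound 4 `COc1ncc(-c2ccc3c(c2)N(C2CC2)C(=O)CO3)cc1NS(=O)(=O)c1ccc(F)cc1` carries cyclopropyl in place of 4-fluorophenyl on an amide-type nitrogen in a ring. Among the measured compounds shown here, the one measured change at that nitrogen is a step that the two limits leave unreadable from compound 1 to compound 2, so it gives no size to carry over. The other measured change, an at least 1.1-fold lower number from compound 2 to compound 3 (0.06 log units; that floor lies within the scatter), concerns chloro in place of methoxy on an aromatic carbon. In this assay, from the compounds shown here alone, therefore, no step beyond the scatter can be expected in either direction, although the outcome remains open. The expected result is a number no higher from compound 2 to compound 4 (the limit leaves the size open). For compound 4 the estimate is 40000 nM, with an expected range from 10000 nM to 80000 nM.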

Compound 4, half-maximal inhibitory concentration: 24300 nM
Compound 4: middle estimate off by 1.6-fold (0.22 log units), on the high side; measured number inside the range.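

In this assay, among the compounds with methoxy on the aromatic carbon, compound 4 alone gives a number rather than a limit, and it alone has a non-aromatic ring on the amide-type nitrogen. Cyclopropyl gives an at least 1.6-fold lower number from compound 2 to compound 4 (0.21 log units; that floor lies within the scatter), and in place of 3-methoxyphenyl it gives an at least 1.6-fold lower number from compound 1 to compound 4 (0.21 log units; that floor lies within the scatter). The true sizes of both steps remain open because compound 1 and compound 2 give only limits: the limit of > 40000 nM in this assay, at which 2 of the 4 values shown sit.

From the compounds shown here alone, whether an amine, a carboxylic acid or a longer chain on that nitrogen would move the number beyond the scatter remains open.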